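Swapping methyl for hydroxy on the shared core

The source may report more compounds than this note shows. Statements on the series, on what has been measured and on what is new or still open speak of the compounds shown alone.

Among the compounds with values here, compound 2 `COc1ccc(-c2ccc(-c3ccc(-c4nc5cc(C)ccc5[nH]4)cc3)cc2)cc1OC` is one of two compounds measured in a functional assay on ZR-75-1 cells (Homo sapiens) for inhibition, read by sulforhodamine B assay; a higher number here means a weaker inhibitor of growth, a lower number a stronger inhibitor of growth. In that assay compound 2 gives 3100 nM, the lowest of the two numbers. Its neighbour, compound 1 `Cc1ccc2[nH]c(-c3ccc(-c4ccc(-c5cccc(Cl)c5)cc4)cc3)nc2c1`, gives 3450 nM in this assay, and a 1.1-fold lower number from compound 1 to compound 2 (0.05 log units; within the scatter), so the two stand on the same footing. Within the data shown here, that step exchanges a 3-chlorophenyl for a 3,4-dimethoxyphenyl on an aromatic carbon, and it is the only step measured so far.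

Compound 3 `COc1ccc(-c2ccc(-c3ccc(-c4nc5c(O)cccc5[nH]4)cc3)cc2)cc1OC` has not yet been measured. It differs from compound 2 elsewhere in the molecule: 4-hydroxy-1H-benzimidazol-2-yl in place of 5-methyl-1H-benzimidazol-2-yl on an aromatic carbon. No measured step touches that part of the structure, so nothing in the two numbers shown speaks directly to this change. Among the measured compounds shown here, the only step available, the exchange of the other aromatic group, stayed within the scatter, and the rest of the shared core is unchanged. The expectation for compound 3 is therefore a step of no change at the digits printed from compound 2 to compound 3 (within the scatter), that is, no change beyond the scatter. Compound 3 is expected to give 3100 nM in this assay, within a range from 1200 nM to 8000 nM.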

Compound 3, concentration for 50% growth inhibition: 2110 nM
Beside the measured number, compound 3's estimate is 1.5-fold (0.17 log units) above it, and the stated range covers the measured number.
By their numbers in this assay, from the lowest: compounds 3, 2 and 1 (each within the scatter of the next).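

In this assay the exchange of 5-methyl-1H-benzimidazol-2-yl for 4-hydroxy-1H-benzimidazol-2-yl gives a 1.5-fold lower number from compound 2 to compound 3 (0.17 log units; within the scatter) and so leaves compound 3 on the same footing as compound 2, which extends the picture to the end of the molecule that the earlier step did not touch. The entering group counts 2 hydrogen-bond donors and 2 hydrogen-bond acceptors against 1 of each in the group that leaves, and this difference in the counts comes with no step beyond the scatter, so among the three compounds shown, a change at either end of the molecule has not yet moved the number beyond the scatter. Nothing else at hand bears on why this step is as small as it is.

Because the group and its place on the ring differ together in this one step, the compounds shown cannot separate the swap of methyl for hydroxy from the shift from the 5-substituted to the 4-substituted name. They also leave open whether an amine or a carboxylic acid standing in place of that hydroxy would give a step beyond the scatter.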